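This account rests on a few compounds, and the source may have more. Where it says the series, first, only, none or still open, it means among the compounds named here.

Measured so far, in a functional assay on PC-3 cells (Homo sapiens) for antiproliferative activity, read by MTT assay, with a stated time of 12 h; on this read-out higher numbers stand for weaker inhibition and lower numbers for stronger inhibition:
compound 1 `COc1cc(OC)c2c(=O)cc(/C=C/c3ccc([N+](=O)[O-])cc3)oc2c1`, a limit of the assay: > 40000 nM
compound 2 `COc1cc(OC)c2c(=O)cc(/C=C/c3ccncc3)oc2c1`, a limit of the assay: > 40000 nM
compound 3 `COc1ccc2c(=O)cc(/C=C/c3ccc(OC(F)(F)F)cc3)oc2c1`, a limit of the assay: > 40000 nM

Compound 2 stands at the limit, not at a number. Every value shown is such a limit, as the limit of > 40000 nM in this assay, at which 3 of the 3 values shown sit, states. Going by the values given here, no step between measured compounds can be given, so no measured size of change is available in this assay. Compound 4 `COc1cc(OC)c2c(=O)cc(/C=C/c3ccc(Cl)cc3)oc2c1` carries 4-chlorophenyl in place of pyridin-4-yl on a double-bonded chain carbon bound to a double-bonded chain carbon. Compound 1 also sits at the limit. Compound 3 also sits at the limit. For compound 4 the expectation is that this assay again reports a limit rather than a number, the estimated step being a step that the limit leaves unreadable from compound 2 to compound 4. The estimate for compound 4 is 60000 nM, with an expected range from 15000 nM to 250000 nM.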

Compound 4, half-maximal inhibitory concentration: > 40000 nM
Compound 4 was reported as a limit; the forecaster's own chance of this, stated with the estimate: 80%; the middle value lies beyond the limit too.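

In this assay compound 4, like compound 1 and compound 2, gives only a limit, so neither step to compound 4 can be read: the limit of > 40000 nM in this assay, at which 4 of the 4 values shown sit. The compounds shown leave open whether any change on the shared core would give a readable number in this assay.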